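Methoxy for Fluoro on the Analogue with the Lowest Number of Three

The source may hold more compounds than are shown below. What is called first, only, known or untested is meant among the compounds shown, and "the series" means these compounds.

Measured so far in a functional assay on the whole organism (strain Wistar albino) for inhibition, with Rattus norvegicus as the target, read by paw edema, with stated times of 1 h and 3 h, at a dose of 0.32 mmol/kg by the intraperitoneal route; on this read-out higher numbers stand for more inhibition at the one dose given (going by the name of the read-out) and lower numbers for less inhibition:
compound 1 `Cc1ccc(-c2nn(-c3ccc(Cl)cc3)cc2/C=N\c2ccc(Cl)cc2)cc1` gives 49.2%
compound 2 `COc1ccc(-c2nn(-c3ccc(Cl)cc3)cc2/C=C\C(=O)c2ccc(Cl)cc2)cc1` gives 66.4%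
compound 3 `Cc1ccc(-c2nn(-c3ccc(Cl)cc3)cc2-c2cc(-c3ccc(Cl)cc3)[nH]c2-c2ccc(F)cc2)cc1` gives 21%

Among these three numbers compound 3 stands lowest. Its nearest neighbour is compound 1, whose value lies higher by a margin beyond the scatter, and the furthest is compound 2, higher still and also beyond the scatter. Going by the values given here, no two of the measured compounds differ in only one place, so no single step between them is available to guide the next case.

Compound 4 `COc1ccc(-c2[nH]c(-c3ccc(Cl)cc3)cc2-c2cn(-c3ccc(Cl)cc3)nc2-c2ccc(C)cc2)cc1` has not yet been measured. It differs from compound 3 in one place only: methoxy in place of fluoro on an aromatic carbon. Nothing in the measured set isolates the effect of methoxy against fluoro on such a ring, so the expected change in this assay is small, with no clear direction, and likely none beyond the scatter. The step from compound 3 to compound 4 is therefore estimated at a number 4 percentage points higher from compound 3 to compound 4 (within the scatter). On that basis compound 4 is expected to give about 25%, within a range from 10% to 42%.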

Compound 4, a percentage reported as inhibition, in the whole organism at one dose (the size of the read-out at that dose, not a potency): 21.3%
The estimate for compound 4 lay 3.7 percentage points above the measured number, within the range that was stated.
By their numbers in this assay, from the lowest: compounds 3 and 4 (each within the scatter of the next); then compound 1; then compound 2.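

In this assay, the change from 4-fluorophenyl to 4-methoxyphenyl gives a number 0.3 percentage points higher from compound 3 to compound 4 (within the scatter), so the two compounds cannot be told apart on this read-out. Going by these compounds alone, this is the only comparison in the set that isolates a change in one place, and it shows that, on this aromatic carbon para to a large group, methoxy and fluoro are interchangeable within the scatter at this one dose, even though methoxy brings a hydrogen-bond acceptor that fluoro does not count. No measurement at hand offers a reason for this outcome.

As far as these compounds go, whether an amine, a carboxylic acid or a longer chain such as butoxy at this position would move the number beyond the scatter stays open. So does whether the same swap from fluoro to methoxy would behave alike on the cores of compound 1 and compound 2, where the numbers stand elsewhere.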